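A few compounds are considered here, and "the series" means these few. Any claim that something is new, unique, unknown or untested is made for them only; others in the source may bear on it.

Compound 1 `CCCCOc1ccc2c(Cl)ccnc2c1` gives the lower of the two numbers recorded so far in a functional assay on HepG2 cells (Homo sapiens) for cytotoxicity, read by MTT assay, with a stated time of 48 h; on this read-out lower numbers stand for stronger inhibition and higher numbers for weaker inhibition: compound 1 gives 2640 nM. Its nearest neighbour is compound 2 `Clc1ccnc2cc(OCCc3ccccc3)ccc12`, which in this assay gives 3310 nM; the step of a 1.3-fold higher number from compound 1 to compound 2 (0.10 log units; within the scatter) stays within the scatter, so the two compounds are not separated on this read-out.

Compound 3 `CC(C)Oc1ccc2c(Cl)ccnc2c1` has not been measured. It differs from compound 1 by isopropyl in place of butyl on an oxygen on an aromatic ring. For the measured compounds named here, the only measured step, a 1.3-fold higher number from compound 1 to compound 2 (0.10 log units; within the scatter), alters the same chain on the aromatic oxygen at a different carbon and moved the number by little; it bears only loosely on a shortening and branching of the butyl. Going by the values given here, with no step that exceeds the scatter anywhere, the expected step of a 1.1-fold higher number from compound 1 to compound 3 (0.03 log units; within the scatter) is taken as none beyond the scatter. Compound 3 is therefore estimated at 2800 nM, with a range of 1200 nM to 6500 nM, in this assay.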

Compound 3, half-maximal inhibitory concentration: 2050 nM
For compound 3 the middle estimate is 1.4-fold (0.14 log units) above the measured one; measured number inside the range.
By their numbers in this assay, from the lowest: compounds 3, 1 and 2 (each within the scatter of the next).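

Replacing butyl with isopropyl on the oxygen on an aromatic ring, a change to the carbon attached directly to that oxygen, gives a 1.3-fold lower number from compound 1 to compound 3 (0.11 log units; within the scatter) in this assay. The earlier step, a 1.3-fold higher number from compound 1 to compound 2 (0.10 log units; within the scatter), changed a chain carbon two bonds along from the oxygen, so both places on this substituent have now been altered without a step beyond the scatter. Among compounds 1, 2 and 3, butoxy, isopropoxy and the phenyl-bearing chain are therefore not separated on this read-out, and no information is available to explain this.

As far as these compounds go, it remains open whether an amine or a carboxylic acid on this chain, or a chain longer than butyl, would separate from these compounds. From the compounds shown here alone, the contribution of the shared core also remains open, as it is identical in all three compounds.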